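A Smaller Group Replaces Trifluoromethoxy in Compound 4

A few compounds are considered here, and "the series" means these few. Any claim that something is new, unique, unknown or untested is made for them only; others in the source may bear on it.

Three compounds share one core and differ only in a single group. Compound 1 `C#Cc1cccc(Nc2ncnc3cc(OC)c(OCCCCC(=O)Nc4ccc(S(N)(=O)=O)cc4)cc23)c1`, compound 2 `COc1ccc(Nc2ncnc3cc(OC)c(OCCCCC(=O)Nc4ccc(S(N)(=O)=O)cc4)cc23)cc1` and compound 3 `COc1cc2ncnc(Nc3ccc(OC(F)(F)F)cc3)c2cc1OCCCCC(=O)Nc1ccc(S(N)(=O)=O)cc1` were tested in a functional assay on A-431 cells (Homo sapiens) for antiproliferative activity, read by MTT assay, with a stated time of 72 h; a lower number here means a stronger inhibitor, a higher number a weaker inhibitor. Compound 1 gives 17700 nM, compound 2 gives 14700 nM, and compound 3 gives 22500 nM. Compound 3 carries the highest of the three numbers, yet a 1.3-fold higher number from compound 1 to compound 3 (0.10 log units; within the scatter) and a 1.5-fold higher number from compound 2 to compound 3 (0.18 log units; within the scatter) both lie within the scatter, so the three compounds cannot be told apart on these numbers.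

Compound 4 `CCc1ccc(Nc2ncnc3cc(OC)c(OCCCCC(=O)Nc4ccc(S(N)(=O)=O)cc4)cc23)cc1` is compound 3 with one change: ethyl in place of trifluoromethoxy on an aromatic carbon. The measured steps that bear on this are the swaps made in the same part of the molecule: a 1.2-fold lower number from compound 1 to compound 2 (0.08 log units; within the scatter), a 1.3-fold higher number from compound 1 to compound 3 (0.10 log units; within the scatter) and a 1.5-fold higher number from compound 2 to compound 3 (0.18 log units; within the scatter). Each of them exchanged one group for another there without moving the number beyond the scatter. The step from compound 3 to compound 4 is therefore expected to be of the same kind, a 1.3-fold lower number from compound 3 to compound 4 (0.10 log units; within the scatter), with no movement in this assay beyond the scatter. Compound 4 is estimated at 18000 nM, with a range from 9000 nM to 36000 nM.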

Compound 4, half-maximal inhibitory concentration: 7220 nM
Compound 4: middle estimate off by 2.5-fold (0.40 log units), on the high side; measured number below the stated range.
By their numbers in this assay, from the lowest: compound 4; then compounds 2, 1 and 3 (each within the scatter of the next).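

Until now, no swap at this position had moved the number in this assay beyond the scatter, so the position could have seemed indifferent to the group it carries. Ethyl is the first group here to break that picture, with a 3.1-fold lower number from compound 3 to compound 4 (0.49 log units; beyond the scatter) and a 2.0-fold lower number from compound 2 to compound 4 (0.31 log units; beyond the scatter) and also a 2.5-fold lower number from compound 1 to compound 4 (0.39 log units; beyond the scatter), each of them modest but beyond the scatter. Ethyl has 2 heavy atoms and no hydrogen-bond acceptor against 5 heavy atoms and 1 acceptor for the trifluoromethoxy it replaces, but no measurement here explains why the number fell.

The compounds shown leave open whether the drop depends on a plain carbon chain at this position. A methyl, a propyl or a tert-butyl group would test that, and an amine there would show whether a nitrogen group can do the same.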